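Two replacements on a shared core against electroshock seizures

The source may hold more compounds than are shown below. What is called first, only, known or untested is meant among the compounds shown, and "the series" means these compounds.

Compound 1, `Cc1ccc(Nc2nnc(Nc3nc(-c4ccc(Br)cc4)cs3)s2)cc1`, gives 100 mg/kg in a functional assay on the whole organism (strain albino) with Mus musculus as the target, in the maximal electroshock model, with a stated time of 0.5 h; a lower number here means that less compound is needed, a higher number that more compound is needed for the effect.
Compound 2, `COc1ccccc1Nc1nnc(Nc2nc(-c3ccc(Br)cc3)cs2)s1`, gives 300 mg/kg.
Compound 3, `Cc1ccc(Nc2nnc(Nc3nc(-c4ccc([N+](=O)[O-])cc4)cs3)s2)cc1`, gives 30 mg/kg.

Compound 1 and compound 2 differ in one place, and that change produces a 3.0-fold higher number from compound 1 to compound 2 (0.48 log units; beyond the scatter). Compound 1 and compound 3 also differ in one place, and that change produces a 3.3-fold lower number from compound 1 to compound 3 (0.52 log units; beyond the scatter), so compound 3 needs the lowest dose of the three measured compounds, with both of its steps to the others beyond the scatter.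

Compound 4, `COc1ccccc1Nc1nnc(Nc2nc(-c3ccc([N+](=O)[O-])cc3)cs2)s1`, has not been measured. It differs from compound 3 by 2-methoxyphenyl in place of 4-methylphenyl on a nitrogen on an aromatic ring. This is the same change that separates compound 1 from compound 2, (2-methoxyphenyl in place of 4-methylphenyl on a nitrogen on an aromatic ring), and it sits at the same kind of place in both pairs. The two cores on which the change is made differ by nitro in place of bromo on an aromatic carbon.

Because the change gave a 3.0-fold higher number from compound 1 to compound 2 (0.48 log units; beyond the scatter), a step of similar size, a 3.3-fold higher number from compound 3 to compound 4 (0.52 log units; beyond the scatter), is expected here. Compound 4 is therefore expected to give about 100 mg/kg. The plausible range for compound 4 is estimated to run from 50 mg/kg to 300 mg/kg.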

Compound 4, minimum effective dose: 300 mg/kg
Compound 4: the middle estimate sits 3.0-fold (0.48 log units) below what was measured; measured number inside the range.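

In this assay, putting 2-methoxyphenyl in place of 4-methylphenyl gives a 10-fold higher number from compound 3 to compound 4 (1.00 log units; beyond the scatter), so the direction of the change carries over from the core of compound 1 to the core of compound 3, but its size does not: the same change on two cores in this assay, a 3.0-fold higher number (0.48 log units; beyond the scatter) from compound 1 to compound 2 and a 10-fold higher number (1.00 log units; beyond the scatter) from compound 3 to compound 4, 3.3-fold (0.52 log units) apart, beyond the scatter of two such steps. The other replacement, nitro in place of bromo, also depends on its surroundings, giving no change at the digits printed from compound 2 to compound 4 (within the scatter), whereas it lowered the number on the core bearing 4-methylphenyl: the same change on two cores in this assay, a 3.3-fold lower number (0.52 log units; beyond the scatter) from compound 1 to compound 3 and no change at the digits printed (within the scatter) from compound 2 to compound 4, 3.3-fold (0.52 log units) apart, beyond the scatter of two such steps. So the two changes do not act independently in these four compounds, and the effect of one cannot simply be added to the effect of the other, although these data do not show why, and two cores cannot show whether the direction would hold on a third.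

On these data alone, it remains open how an amine or a carboxylic acid in place of the nitro or bromo would behave. As far as these compounds go, it is equally open whether the same dependence would appear with a longer chain in place of the 4-methylphenyl.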